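The source may hold more compounds than are shown below. What is called first, only, known or untested is meant among the compounds shown, and "the series" means these compounds.

Compound 2 `N#CC1=C(N)Oc2c(N)cc3nc4ccccc4nc3c2C12C(=O)N(Cc1cnnn1-c1ccc([N+](=O)[O-])cc1)c1ccccc12` gives in a functional assay on A549 cells (Homo sapiens) for antiproliferative activity, read by MTT assay, with a stated time of 48 h (a lower number here means a stronger inhibitor, a higher number a weaker inhibitor), only a limit, > 50000 nM. Compound 1 `N#CC1=C(N)Oc2c(N)cc3nc4ccccc4nc3c2C12C(=O)N(Cc1cnnn1-c1ccccc1Cl)c1ccccc12` gives 29800 nM in this assay. Within the data shown here, the step of an at least 1.6-fold higher number from compound 1 to compound 2 (0.22 log units; that floor lies within the scatter) is the only measured change on the aromatic nitrogen, and it runs into (the limit of > 50000 nM in this assay, at which 1 of the 2 values shown sits), so its real size stays open. Compound 3 `CCc1cccc(CC)c1-n1nncc1CN1C(=O)C2(C(C#N)=C(N)Oc3c(N)cc4nc5ccccc5nc4c32)c2ccccc21` differs from compound 2 by 2,6-diethylphenyl in place of 4-nitrophenyl on an aromatic nitrogen. Among the measured compounds shown here, no measured step covers this change, and both measured values sit near or at the limit of this assay, so compound 3 is expected to remain weak. The estimate for compound 3 is 45000 nM, from 15000 nM to 100000 nM, and the expected step of an at least 1.1-fold lower number from compound 2 to compound 3 (0.04 log units; that floor lies within the scatter) lies within the scatter.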

Compound 3, half-maximal inhibitory concentration: > 50000 nM
Compound 3: no number, only a limit; the forecaster's own chance of this, stated with the estimate: 45%; at least 1.1-fold (0.04 log units) between middle value and limit.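

In this assay, on these data alone, 2,6-diethylphenyl in place of 2-chlorophenyl on the aromatic nitrogen gives an at least 1.6-fold higher number from compound 1 to compound 3 (0.22 log units; that floor lies within the scatter), so the true size of this step stays open. This carbon-only group, with no hydrogen-bond acceptors, ends at the same assay limit as 4-nitrophenyl, which has two. The step between compound 2 and compound 3 cannot be read, and the limit now caps most of this small set: the limit of > 50000 nM in this assay, at which 2 of the 3 values shown sit.

As far as these compounds go, what an unsubstituted phenyl or a 4-aminophenyl on this nitrogen would give stays open. Also open, from the compounds shown here alone, is whether any group here moves the value clearly away from compound 1 at 29800 nM.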